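This account rests on a few compounds, and the source may have more. Where it says the series, first, only, none or still open, it means among the compounds named here.

Measured so far:
Compound 1, `CC(=O)N1CCN(c2ccc(Nc3ncc(C(F)(F)F)c(N4Cc5cccc(N(C)S(C)(=O)=O)c5C4)n3)cc2)CC1`, gives 970 nM in a functional assay on OVCAR-3 cells (Homo sapiens) for antiproliferative activity, read by spectrophotometry, with a stated time of 2 days; on this read-out higher numbers stand for weaker inhibition of growth and lower numbers for stronger inhibition of growth.
Compound 2, `COc1cc(Nc2ncc(C(F)(F)F)c(N3Cc4cccc(N(C)S(C)(=O)=O)c4C3)n2)c(OC)cc1Cl`, gives > 30000 nM in this assay.

The entry for compound 2 is a limit of the assay rather than a measured number (the limit of > 30000 nM in this assay, at which 1 of the 2 values shown sits). For the measured compounds named here, compound 2 thus stands at the weak end of what has been seen, while compound 1 is the only compound with a definite number. Going by the values given here, no single step between two measured compounds is available, so the pair can only be read as two separate results.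

Compound 3, `Cc1ccc(Nc2ncc(C(F)(F)F)c(N3Cc4cccc(N(C)S(C)(=O)=O)c4C3)n2)c(C)c1`, keeps the whole shared core of compound 2 and changes only one part, (2,4-dimethylphenyl in place of 4-chloro-2,5-dimethoxyphenyl on a nitrogen on an aromatic ring). The group that enters is smaller and carries no hydrogen-bond acceptors, as the counted difference shows.

The step from compound 2 to compound 3 in this assay is expected to go towards stronger inhibition of growth, estimated as an at least 5.0-fold lower number from compound 2 to compound 3 (0.69 log units; beyond the scatter), since compound 2 sits at the limit and there is room only downward. Compound 3 is estimated at 6000 nM, with a range from 1500 nM to 30000 nM.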

Compound 3, concentration for 50% growth inhibition: > 30000 nM
Compound 3 ended at the assay's limit; the forecaster's own chance of this, stated with the estimate: 30%; middle value at least 5.0-fold (0.69 log units) away from the limit.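

In this assay compound 3 gives > 30000 nM, which is a limit of the assay and not a number. For the compounds shown here, compound 2 ends at the same limit, so no step between compound 2 and compound 3 can be read: the limit of > 30000 nM in this assay, at which 2 of the 3 values shown sit. From the compounds shown here alone, what stays open is whether 2,4-dimethylphenyl and 4-chloro-2,5-dimethoxyphenyl differ at all in this assay.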